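Algal inhibition notes: adding an ester next to chloro

A few compounds are considered here, and "the series" means these few. Any claim that something is new, unique, unknown or untested is made for them only; others in the source may bear on it.

Compound 1 `O=c1c2c([s+]([O-])n1-c1ccc(Cl)cc1)CCCC2` gives 30200 nM in a functional assay on the whole organism for inhibition, with Scenedesmus acutus as the target, with a stated time of 20 min; a higher number here means a weaker inhibitor, a lower number a stronger inhibitor. Compound 2 `O=c1c2c(sn1-c1ccc([N+](=O)[O-])cc1)CCCC2` gives 23400 nM in this assay, and compound 3 `O=c1c2c(sn1-c1ccc(C(F)(F)F)cc1)CCCC2` gives 74100 nM. Compound 1 thus holds the second highest of the three numbers; its gap to compound 2 lies within the scatter, while its gap to compound 3 lies beyond it. Among the measured compounds shown here, the single measured step, a 3.2-fold higher number from compound 2 to compound 3 (0.50 log units; beyond the scatter), exchanges one group for another on an aromatic carbon. The change to compound 4 `CC(C)OC(=O)c1cc(-n2c(=O)c3c([s+]2[O-])CCCC3)ccc1Cl` is different in kind: isopropoxycarbonyl in place of hydrogen on an aromatic carbon, the new group entering ortho to a chloro group. For the measured compounds named here, no measured step bears on this change, so the expected step is a 1.0-fold lower number from compound 1 to compound 4 (0.00 log units; within the scatter), meaning none beyond the scatter but with wide uncertainty. Compound 4 is estimated at 30000 nM, with a range from 7500 nM to 120000 nM.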

Compound 4, half-maximal inhibitory concentration: 51300 nM
Estimate against measurement, compound 4: 1.7-fold (0.23 log units) below; measured number inside the range.
By their numbers in this assay, from the lowest: compounds 2, 1, 4 and 3 (each within the scatter of the next, the first and the last beyond it).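

In this assay, the step of a 1.7-fold higher number from compound 1 to compound 4 (0.23 log units; within the scatter) shows that isopropoxycarbonyl can enter on this aromatic carbon, ortho to a chloro group, without a shift beyond the scatter. The earlier step only exchanged one group for another on an aromatic carbon, whereas this one replaces hydrogen at a new place on the ring. No measurement bearing on why the number holds is available here.

From the compounds shown here alone, a carboxylic acid, an amine or a methyl ester at this place remains open. So does whether isopropoxycarbonyl behaves alike with nitro or trifluoromethyl in place of chloro.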